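The source may report more compounds than this note shows. Statements on the series, on what has been measured and on what is new or still open speak of the compounds shown alone.

Compound 3 `Cn1c(-c2ccc(C#N)cc2)cnc1NC(=O)c1ccc(F)cc1` carries a methyl on the aromatic nitrogen of the shared core and a cyano on the pendant six-membered ring. In a toxicity assay on THP-1 cells (Homo sapiens) for inhibition (on this read-out lower numbers stand for higher toxicity in this test and higher numbers for lower toxicity in this test), compound 3 gives only > 50000 nM, which is a limit of the test rather than a number, so compound 3 stands among the least toxic entries shown here, alongside compound 1 `COc1ccc(-c2cnc(NC(=O)c3ccc(F)cc3)n2Cc2ccccc2)cc1`. In this assay compound 1 gives > 100000 nM, again a limit and not a measured number. Compound 2 `COc1ccc(-c2cnc(NC(=O)c3ccc(F)cc3)n2-c2ccccc2)cc1`, by contrast, gives 8800 nM in this assay. Among the compounds with values here, the only step measured is an at least 11-fold lower number from compound 1 to compound 2 (1.05 log units; beyond the scatter), a change on the aromatic nitrogen that does not touch the pendant ring. Compound 4 `COc1ccc(-c2cnc(NC(=O)c3ccc(F)cc3)n2C)cc1` keeps the methyl of compound 3 and differs from it by methoxy in place of cyano on an aromatic carbon. Within the data shown here, no measured step concerns this exchange, so the step that the limit leaves unreadable from compound 3 to compound 4 is expected to stay within the scatter, most likely ending again at a limit. Compound 4 is therefore estimated at 80000 nM, between 30000 nM and 300000 nM.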

Compound 4, half-maximal cytotoxic concentration: >= 50000 nM
Compound 4 ended at the assay's limit (the forecaster's own chance of this, stated with the estimate: 70%); the middle value does not contradict the limit.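

Methyl in place of phenyl on the aromatic nitrogen gives an at least 5.6-fold higher number from compound 2 to compound 4 (0.75 log units; beyond the scatter) in this assay, so moving away from phenyl in a second direction also leads to a higher number, meaning lower toxicity in this test. Together with an at least 11-fold lower number from compound 1 to compound 2 (1.05 log units; beyond the scatter), this leaves compound 2, with its phenyl, as the only one of the three methoxy compounds with a measured number rather than a limit. The steps from compound 3 to compound 4 and from compound 1 to compound 4 cannot be read, as both ends of each are limits, so the exchange of 4-cyanophenyl for 4-methoxyphenyl shows no measurable effect here.

The compounds shown leave open how an ethyl or a cyclohexyl on the aromatic nitrogen would behave. They also leave open whether an amine or a carboxylic acid on the pendant ring would change the number when phenyl sits on that nitrogen.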